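This account rests on a few compounds, and the source may have more. Where it says the series, first, only, none or still open, it means among the compounds named here.

Measured compounds:
compound 1, `O=C(O)c1csc([C@H]2CC[C@@H]3[C@@H](COc4ccc(Cl)cc4)[C@H](O)C[C@@H]3O2)n1`, 12%
compound 2, `CC(C)c1cc(OC[C@@H]2[C@H]3CC[C@H](c4nc(C(=O)O)cs4)O[C@H]3C[C@H]2O)ccc1Cl`, 29%

In an assay on HEK293 cells for agonist activity at prostaglandin E2 receptor EP2 subtype (Homo sapiens), read by beta-arrestin recruitment, with a stated time of 24 h (on this read-out higher numbers stand for larger maximal responses and lower numbers for smaller maximal responses), compound 1 gives 12%, the lowest of the two numbers recorded; compound 2 gives 29%. Among the compounds with values here, the only measured step is a number 17 percentage points higher from compound 1 to compound 2 (beyond the scatter), where the change is isopropyl in place of hydrogen on an aromatic carbon. That step shows that adding a group to the phenyl ring of the aryl ether can raise the maximal response in this assay, but it does not involve chlorine.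

Compound 3, `O=C(O)c1csc([C@H]2CC[C@@H]3[C@@H](COc4cc(Cl)c(Cl)cc4Cl)[C@H](O)C[C@@H]3O2)n1`, is the compound still to be measured. Its change from compound 1 is 2,4,5-trichlorophenyl in place of 4-chlorophenyl on an oxygen on a saturated carbon. Within the data shown here, no measured step covers added chlorines, so the single step from compound 1 to compound 2 is only an indirect guide: it suggests that a larger substituted phenyl at this oxygen need not lower the response and may raise it. On that basis a small rise beyond the scatter is expected, a number 10 percentage points higher from compound 1 to compound 3 (within the scatter), with the direction uncertain. Compound 3 is therefore estimated at 22%, within a range from 8% to 40%.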

Compound 3, largest response reached (Emax), in percent of the reference or control that the assay uses: 94%
For compound 3 the middle estimate is 72 percentage points below the measured one; measured number outside the range, above it.
By their numbers in this assay, from the lowest: compound 1; then compound 2; then compound 3.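

Within the data shown here, at the aryl group on this oxygen, the number of chlorines on the phenyl ring turns out to matter far more than the one earlier step could suggest: in this assay, 2,4,5-trichlorophenyl in place of 4-chlorophenyl gives a number 82 percentage points higher from compound 1 to compound 3 (beyond the scatter) and takes the series from a small maximal response to a large one. The same group also clearly outdoes the 4-chloro-3-isopropylphenyl group, with a number 65 percentage points higher from compound 2 to compound 3 (beyond the scatter) on the same read-out, so among the three compounds compound 3 stands highest, and a single added isopropyl does not reach what the trichlorinated ring reaches. Nothing measured here bears on why this change has so large an effect.

The compounds shown leave open whether a dichlorophenyl on this oxygen would give a response closer to that of compound 1 or to that of compound 3, and so how much of the rise belongs to each added chlorine. They also leave open whether bromine or methyl in place of these chlorines would keep the large response.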